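The source may hold more compounds than are shown below. What is called first, only, known or untested is meant among the compounds shown, and "the series" means these compounds.

Compound 1, `COc1ccccc1C(C1=C(O)C(=O)c2ccccc2C1=O)c1c[nH]c2ccccc12`: > 200000 nM
Compound 2, `O=C1C(O)=C(C(c2ccc([N+](=O)[O-])cc2)c2c[nH]c3ccccc23)C(=O)c2ccccc21`: > 200000 nM

In a toxicity assay (Homo sapiens) for cytotoxicity, read by MTT assay, with a stated time of 48 h (on this read-out lower numbers stand for stronger inhibition and higher numbers for weaker inhibition), compound 1 gives > 200000 nM, which is a limit of the assay and not a number. Compound 2 gives > 200000 nM in this assay, again a limit rather than a number. The change between them, a step that the two limits leave unreadable from compound 1 to compound 2, is therefore left unreadable, since both values sit at the limit of > 200000 nM in this assay, at which 2 of the 2 values shown sit. Among the compounds with values here, compound 2 thus stands at the limit of this assay with no number of its own, and the one further value shown beside it is also a limit.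

Compound 3, `O=C1C(O)=C(C(c2ccc([N+](=O)[O-])cc2)c2c[nH]c3ccc(Br)cc23)C(=O)c2ccccc21`, differs from compound 2 by bromo in place of hydrogen on an aromatic carbon. No measured step touches this position, and the only step available is unreadable, so nothing shown gives a direction or a size for this change. Compound 3 is therefore expected to remain near the limit, with a fair chance that this assay again reports only a limit. The estimate for compound 3 is 150000 nM, with a range from 40000 nM to 250000 nM. This estimate corresponds to an expected step of an at least 1.3-fold lower number from compound 2 to compound 3 (0.12 log units; that floor lies within the scatter), with no shift beyond the scatter anticipated.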

Compound 3, half-maximal inhibitory concentration: 45200 nM
Compound 3: middle estimate off by 3.3-fold (0.52 log units), on the high side; the measured number falls inside the stated range.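

In this assay, within the data shown here, the change from 1H-indol-3-yl to 5-bromo-1H-indol-3-yl gives the first step that can be read, an at least 4.4-fold lower number from compound 2 to compound 3 (0.64 log units; beyond the scatter), whereas the only earlier step could not be read. This shows that the read-out responds to a single bromine atom at this aromatic carbon, which is meta to a fused ring and para to a fused ring, a place that no earlier comparison touched. Compound 3 is the only one of the three with a number of its own, and the other two remain at the limit: the limit of > 200000 nM in this assay, at which 2 of the 3 values shown sit.

What stays open is whether the drop belongs to bromo alone or depends on the 4-nitrophenyl group that compound 2 and compound 3 share, as the compounds shown offer no bromo counterpart of compound 1 with its 2-methoxyphenyl group. They also leave open what chloro, a methoxy group, an amine or a carboxylic acid would give at this same aromatic carbon, and so whether the step is particular to bromo or is seen with other groups there.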